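Sulfonyl chain variation on the shared cyclopropyl core

This account rests on a few compounds, and the source may have more. Where it says the series, first, only, none or still open, it means among the compounds named here.

Measured so far in an ADME assay on HEp-2 cells (Homo sapiens) for cytotoxicity; a higher number here means that more compound is tolerated, a lower number that less compound is tolerated:
- compound 1 `O=c1n(Cc2nc3ccccc3n2CCCC(F)(F)F)c2cnccc2n1C1CC1`: 55700 nM
- compound 2 `O=c1n(Cc2nc3ccccc3n2CCCCCO)c2cnccc2n1C1CC1`: a limit only, > 229000 nM
- compound 3 `CS(=O)(=O)CCCn1c(Cn2c(=O)n(C3CC3)c3ccncc32)nc2ccccc21`: > 230000 nM; > 227000 nM (2 entries)

Compound 2 stands at a limit, not at a number; it sits at the limit of > 229000 nM in this assay, at which 1 of the 3 values shown sits. Within the data shown here, the one measured step that touches it is an at least 4.1-fold higher number from compound 1 to compound 2 (0.61 log units; beyond the scatter), that is, the move from compound 1 to compound 2 pushed the read-out up to the assay's ceiling.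

Compound 4 `CCS(=O)(=O)CCCn1c(Cn2c(=O)n(C3CC3)c3ccncc32)nc2ccccc21` is the next member. Its change from compound 2 is ethylsulfonyl in place of 2-hydroxyethyl on a saturated chain carbon, three bonds along the chain from an aromatic nitrogen. Among the measured compounds shown here, no measured step copies this change, so the expectation rests on two things: the upward step from compound 1 to compound 2 that ends at a limit, and (the several entries of compound 3 in this assay, > 230000 nM; > 227000 nM (2 entries)), which shows that a sulfonyl-bearing chain on this core also runs into the ceiling. For compound 4 the expected step is therefore a step that the limit leaves unreadable from compound 2 to compound 4, none beyond the scatter, with a limit the most likely outcome. Compound 4 is estimated at 240000 nM, between 110000 nM and 550000 nM.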

Compound 4, half-maximal cytotoxic concentration: > 227000 nM
Compound 4: no number, only a limit; the forecaster's own chance of this, stated with the estimate: 75%; the middle value does not contradict the limit.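

Compound 4 carries ethylsulfonyl on a saturated chain carbon, three bonds along the chain from an aromatic nitrogen, and gives only a limit in this assay, so compound 3 is not the only sulfonyl-bearing chain to do so: the several entries of compound 3 in this assay, > 230000 nM; > 227000 nM (2 entries)

Replacing trifluoromethyl with ethylsulfonyl gives an at least 4.0-fold higher number from compound 1 to compound 4 (0.61 log units; beyond the scatter), a second replacement at this place that ends at a limit, after an at least 4.1-fold higher number from compound 1 to compound 2 (0.61 log units; beyond the scatter). The comparison of compound 2 with compound 4 cannot be read, as both values are limits.

Among compounds 2, 3 and 4, any order in this assay stays unknown, and compound 1 is the only one of the four with a single number. Also open, as far as these compounds go, is how a carboxylic acid or an amine at this place would read in this assay.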